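Methoxy on the aromatic ring of the propargylamine series

The compounds below may be only part of what the source reports. "The series", "measured", "known", "first", "only" and "open" are said of these compounds alone.

Compound 1 `C#CCN(C)CCCCOc1ccc(C(C)=O)cc1` is the parent of this short series. In an ADME assay on BTI cells for inhibition of Amine oxidase [flavin-containing] A (Homo sapiens), read by fluorescence and Amplex Red, with a stated time of 15 min, tested at 100 uM (a higher number here means more inhibition at the concentration tested (going by the name of the read-out), a lower number less inhibition), compound 1 gives 28.6%. Going by the values given here, compound 2 `C#CCN(C)CCCCCCOc1ccc(C(C)=O)cc1` is the only other member with a number so far, and in this assay compound 2 gives 37.3%; the step of a number 8.7 percentage points higher from compound 1 to compound 2 (within the scatter) keeps the two within the scatter of each other, so on these numbers they cannot be told apart.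

Compound 3 `C#CCN(C)CCCCOc1ccc(C(C)=O)cc1OC` has not yet been measured. It differs from compound 1 by methoxy in place of hydrogen on an aromatic carbon. Among the compounds with values here, the single measured step, a number 8.7 percentage points higher from compound 1 to compound 2 (within the scatter), concerns the saturated chain and not the aromatic ring, so no measured step bears directly on this change. Nothing in the series therefore points to a shift in this assay beyond the scatter in either direction, and the step of a number 1.4 percentage points higher from compound 1 to compound 3 (within the scatter) is expected to remain small. On that basis compound 3 is estimated to give 30% in this assay, with a range from 12% to 52% to allow for the absence of any ring-substitution step in the series.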

Compound 3, a percentage reported as inhibition, at one concentration (the size of the read-out at that concentration, not a potency): 21.1%
Estimate against measurement, compound 3: 8.9 percentage points above; the measured number falls inside the stated range.
By their numbers in this assay, from the lowest: compounds 3, 1 and 2 (each within the scatter of the next, the first and the last beyond it).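

Methoxy in place of hydrogen on this aromatic carbon, ortho to a large group and meta to an acetyl group, is the first change to the ring in the series, and in this assay it gives a number 7.5 percentage points lower from compound 1 to compound 3 (within the scatter) and so leaves compound 3 indistinguishable from compound 1 on this read-out. The ring position therefore takes a substituent of 2 heavy atoms, with 1 hydrogen-bond acceptor, without a step beyond the scatter, and the same holds so far for the chain change, a number 8.7 percentage points higher from compound 1 to compound 2 (within the scatter) in the same assay. No measurement at hand accounts for the size of either step, so the methoxy step stands as a bare observation.

Still open, from the compounds shown here alone, is whether another group on this aromatic carbon, such as chlorine, trifluoromethyl, an amine or a carboxylic acid, would move the number beyond the scatter, or whether methoxy would read the same on the longer chain of compound 2. Also open, going by these compounds, is how the series responds where the acetyl group itself gives way to another group, such as a nitrile or an amide.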